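The source may report more compounds than this note shows. Statements on the series, on what has been measured and on what is new or still open speak of the compounds shown alone.

Measured so far:
Compound 1 `CN1CCC[C@H]1[C@@H]1COc2ccc(CO)cc2O1`: 51000 nM
Compound 2 `CN1CCC[C@@H]1[C@H]1COc2ccc(O)cc2O1`: 3500 nM

In an assay on Cerebral cortex (strain Sprague-Dawley) for displacement of a labelled ligand from Neuronal acetylcholine receptor; alpha4/beta2 (Rattus norvegicus) (on this read-out higher numbers stand for weaker inhibition and lower numbers for stronger inhibition), compound 2 holds the lowest of the two numbers; compound 1 gives a number that is higher by a gap beyond the scatter. Compound 3 `CN1CCC[C@H]1[C@@H]1COc2ccc(O)cc2O1` is not yet measured. Compared with compound 2, (the two compounds have the same atoms and bonds and differ only in configuration as drawn: 2 of 2 stereo elements differ (all stereocentres are inverted: mirror images); a stereocentre at a saturated ring carbon is drawn R in compound 2 and S in compound 3; a stereocentre at a saturated ring carbon is drawn S in compound 2 and R in compound 3). Among the compounds with values here, no measured pair shows a mirror-image step, so its size is unknown; mirror images at this target often differ beyond the scatter, and a weakening step is expected: a 4.3-fold higher number from compound 2 to compound 3 (0.63 log units; beyond the scatter). Compound 3 is therefore estimated at 15000 nM, in a range from 3000 nM to 70000 nM.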

Compound 3, inhibition constant: 12 nM
Beside the measured number, compound 3's estimate is 1300-fold (3.10 log units) above it; measured number outside the range, below it.
By their numbers in this assay, from the lowest: compound 3; then compound 2; then compound 1.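

In this assay, inverting both stereocentres gives a 290-fold lower number from compound 2 to compound 3 (2.46 log units; beyond the scatter), so configuration alone separates a weak compound from a strong one, and the result can be assigned to stereochemistry: the fact that compounds 2 and 3 differ only in the configuration as drawn. With the configuration of compound 3 held, hydroxy in place of hydroxymethyl on the aromatic carbon gives a 4300-fold lower number from compound 1 to compound 3 (3.63 log units; beyond the scatter), so this position also responds strongly to a small change of group. From the compounds shown here alone, whether an amine or a methoxy group at this carbon would match hydroxy remains open. So does the effect of inverting only one stereocentre.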